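The compounds below may be only part of what the source reports. "The series", "measured", "known", "first", "only" and "open" are said of these compounds alone.

Three close relatives share one core. Compound 3, `O=S(=O)(NCCNc1nccc(-c2c(-c3cccc(F)c3)nc3sccn23)n1)c1ccc(F)cc1`, gives 9450 nM in a functional assay on SK-MEL-28 cells (Homo sapiens) for cytotoxicity, read by MTT assay; on this read-out higher numbers stand for weaker inhibition and lower numbers for stronger inhibition. Compound 1, `O=S(=O)(NCCCNc1nccc(-c2c(-c3cccc(F)c3)nc3sccn23)n1)c1cccc(F)c1`, gives 8550 nM, and compound 2, `O=S(=O)(NCCCNc1nccc(-c2c(-c3cccc(F)c3)nc3sccn23)n1)c1ccccc1`, gives 6850 nM; the steps of a 1.1-fold higher number from compound 1 to compound 3 (0.04 log units; within the scatter) and a 1.4-fold higher number from compound 2 to compound 3 (0.14 log units; within the scatter) place compound 3 within the scatter of both neighbours. Compound 4, `O=S(=O)(NCCNc1nccc(-c2c(-c3cccc(F)c3)nc3sccn23)n1)c1ccc(Cl)cc1`, is not yet measured; it differs from compound 3 by chloro in place of fluoro on an aromatic carbon. Going by the values given here, the only measured step that alters a halogen on an aromatic carbon is a 1.2-fold lower number from compound 1 to compound 2 (0.10 log units; within the scatter), which stayed within the scatter, though there fluoro gave way to hydrogen rather than chloro. Among the compounds with values here, no measured pair here compares chloro with fluoro directly. The step of a 1.1-fold lower number from compound 3 to compound 4 (0.02 log units; within the scatter) is therefore expected to stay within the scatter. Compound 4 is estimated at 9000 nM, ranging from 4500 nM to 18000 nM.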

Compound 4, half-maximal inhibitory concentration: 18600 nM
Compound 4: middle estimate off by 2.1-fold (0.32 log units), on the low side; measured number outside the range, above it.
By their numbers in this assay, from the lowest: compounds 2, 1, 3 and 4 (each within the scatter of the next, the first and the last beyond it).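

In this assay, chloro and fluoro on this aromatic carbon can now be compared directly, and the swap stays within the scatter (a 2.0-fold higher number from compound 3 to compound 4 (0.29 log units; within the scatter)). Going by these compounds alone, compound 4 nevertheless brings the first steps in this set that go beyond the scatter (a 2.7-fold higher number from compound 2 to compound 4 (0.43 log units; beyond the scatter); a 2.2-fold higher number from compound 1 to compound 4 (0.34 log units; beyond the scatter)), each modest and each changing the sulfonyl ring and the chain together. Nothing shown here explains these numbers. On these data alone, whether bromo or methoxy on the same carbon would give a similar number remains open. So does how the 4-chlorophenyl group reads on the longer chain of compound 1.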